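This account rests on a few compounds, and the source may have more. Where it says the series, first, only, none or still open, it means among the compounds named here.

Measured compounds:
- compound 1, `Cc1ccc2nc(SCc3cc(=O)oc4cc(OS(=O)(=O)c5ccc(F)cc5)ccc34)[nH]c(=O)c2c1`: 86400 nM
- compound 2, `Cc1ccc(S(=O)(=O)Oc2ccc3c(CSC4=NCCC(=O)N4)cc(=O)oc3c2)cc1`: 60200 nM

In an ADME assay on Vero cells (Chlorocebus sabaeus) for cytotoxicity, read by polymerase chain reaction, with a stated time of 18 h (a lower number here means that less compound is tolerated, a higher number that more compound is tolerated), compound 2 gives 60200 nM. Compound 1, which carries a different core, gives 86400 nM in this assay; the two numbers lie within the usual scatter of each other, so no difference between them can be read from this pair.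

Compound 3, `O=C1CCN=C(SCc2cc(=O)oc3cc(OS(=O)(=O)c4ccc(F)cc4)ccc23)N1`, has not yet been measured. It differs from compound 2 in one place: fluoro in place of methyl on an aromatic carbon. For the measured compounds named here, no pair of measured compounds shows the effect of this change, so there is nothing to lean on beyond the fact that compound 1, which also carries a fluoro group, is close to compound 2 in this assay. The expected step of a 1.1-fold higher number from compound 2 to compound 3 (0.03 log units; within the scatter) is small, with no direction beyond the scatter.

Compound 3 is expected to give about 65000 nM in this assay, likely between 30000 nM and 140000 nM.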

Compound 3, half-maximal cytotoxic concentration: 111000 nM
Estimate against measurement, compound 3: 1.7-fold (0.23 log units) below; low and high end bracket the measured number.
By their numbers in this assay, from the lowest: compounds 2, 1 and 3 (each within the scatter of the next).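

In this assay, for the compounds shown here, this is the first direct reading of fluoro in place of methyl on this aromatic carbon, para to a large group, and the step lies within the scatter (a 1.8-fold higher number from compound 2 to compound 3 (0.27 log units; within the scatter)), so 4-methylphenyl and 4-fluorophenyl cannot be told apart here. With the fluoro group kept, replacing the larger group on the sulfur in compound 1 with the six-membered non-aromatic ring also stays within the scatter (a 1.3-fold higher number from compound 1 to compound 3 (0.11 log units; within the scatter)), so this much bigger exchange cannot be told apart either. No measurement at hand offers an explanation for these small steps.

Going by these compounds, it remains open whether an amine or a carboxylic acid in place of the fluoro group would move the number beyond the scatter. Also open, on these data alone, is whether a longer chain on the sulfur, in place of the ring, would do so.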